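Lengthening the Alkoxy Chain from Butoxy to Hexyloxy

The source may hold more compounds than are shown below. What is called first, only, known or untested is meant among the compounds shown, and "the series" means these compounds.

For the measured compounds named here, compound 3 `CCCCOc1nccnc1C1CN2CCC1CC2` stands highest of the three numbers measured so far in a functional assay on A9L-m1 cells with A9 (Mus musculus) as the target (on this read-out lower numbers stand for smaller maximal responses and higher numbers for larger maximal responses), giving 15%. Compound 1 `Cc1nccnc1C1CN2CCC1CC2` gives 4% and compound 2 `CCOc1nccnc1C1CN2CCC1CC2` gives 1% in this assay, both beyond the scatter below compound 3. Compound 4 `CCCCCCOc1nccnc1C1CN2CCC1CC2` differs from compound 3 by ethyl in place of hydrogen on a saturated chain carbon, four bonds along the chain from an oxygen on an aromatic ring. Going by the values given here, the one step of the same kind measured so far is a number 14 percentage points higher from compound 2 to compound 3 (beyond the scatter), a modest rise; the related step of a number 11 percentage points higher from compound 1 to compound 3 (beyond the scatter) points the same way. Because of a number 14 percentage points higher from compound 2 to compound 3 (beyond the scatter) a further modest rise, or a change within the scatter, is expected for compound 4, namely a number 7 percentage points higher from compound 3 to compound 4 (within the scatter). Compound 4 is therefore estimated at 22%, with a range from 8% to 40%.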

Compound 4, largest response reached (reported as maximum), in percent of the reference or control that the assay uses: 40%
For compound 4 the middle estimate is 18 percentage points below the measured one, within the range that was stated.
By their numbers in this assay, from the lowest: compounds 2 and 1 (each within the scatter of the next); then compound 3; then compound 4.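

The rise in this assay does not stop at butoxy: ethyl in place of hydrogen, four bonds along the chain from the oxygen, still gives a step beyond the scatter (a number 25 percentage points higher from compound 3 to compound 4 (beyond the scatter)). Against the short groups, hexyloxy brings the first large steps at this position (a number 39 percentage points higher from compound 2 to compound 4 (beyond the scatter)) and (a number 36 percentage points higher from compound 1 to compound 4 (beyond the scatter)).

As far as these compounds go, whether a longer chain such as octyloxy goes on raising the number, or an amine at the end of the hexyloxy chain keeps the rise, stays open. Nothing available explains the rise.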